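Swapping Dimethylamino for Pyrrolidin-1-yl

A few compounds are considered here, and "the series" means these few. Any claim that something is new, unique, unknown or untested is made for them only; others in the source may bear on it.

In a functional assay on K562 cells (Homo sapiens) for antiproliferative activity, read by MTT assay, with a stated time of 24 h (on this read-out higher numbers stand for weaker inhibition and lower numbers for stronger inhibition), compound 1 `COc1ccc(C(=O)/C=C/c2cccc(F)c2)c2c1C=CC(C)(C)O2` returns > 10000 nM as its result, which is a limit and not a number. Within the data shown here, compound 2 `COc1ccc(C(=O)/C=C/c2ccc(N(C)C)cc2)c2c1C=CC(C)(C)O2` gives 3500 nM in this assay and so holds the only true number so far. Just one measured step bears on what follows, namely an at least 2.8-fold lower number from compound 1 to compound 2 (0.45 log units; beyond the scatter) when 4-(dimethylamino)phenyl takes the place of 3-fluorophenyl. Compound 3 `COc1ccc(C(=O)/C=C/c2ccc(N3CCCC3)cc2)c2c1C=CC(C)(C)O2` differs from compound 2 in one group: pyrrolidin-1-yl in place of dimethylamino on an aromatic carbon with pyrrolidin-1-yl in place of dimethylamino on an aromatic carbon. The measured step exchanged a whole substituent and never tested this smaller swap, so it is only a weak guide. The expected change is therefore small, with a 1.2-fold lower number from compound 2 to compound 3 (0.07 log units; within the scatter) estimated to stay within the scatter. Compound 3 is expected at 3000 nM with an estimated range of 1200 nM to 8000 nM in this assay once measured.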

Compound 3, half-maximal inhibitory concentration: 6180 nM
Estimate against measurement, compound 3: 2.1-fold (0.31 log units) below; low and high end bracket the measured number.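

Replacing dimethylamino with pyrrolidin-1-yl, on an aromatic carbon para to a large group, gives a 1.8-fold higher number from compound 2 to compound 3 (0.25 log units; within the scatter) in this assay. The earlier step exchanged a whole substituent, whereas this one compares two nitrogen groups at the same place, and this read-out cannot tell them apart even though the nitrogen's two carbon arms are now closed into a five-membered non-aromatic ring. Nothing in the available data bears on why these two groups read alike.

The compounds shown leave open how a piperidin-1-yl or a morpholin-4-yl group, with a larger ring or a second hetero atom, would read at this carbon. From the compounds shown here alone, a plain primary amine there is equally open, so whether the carbons on the nitrogen matter at all remains unknown.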